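From 4-methoxyoxan-4-yl to oxan-2-yl in compound 2

This account rests on a few compounds, and the source may have more. Where it says the series, first, only, none or still open, it means among the compounds named here.

Of the compounds shown here, three sharing one core have been measured in a functional assay on HeLa cells (Homo sapiens) for antiproliferative activity; on this read-out lower numbers stand for stronger inhibition and higher numbers for weaker inhibition. Compound 1 `C/C1=C\[C@@H](O)C(=O)/C=C/C=C/c2csc(n2)[C@@H](C)N2C(=O)C[C@@]([C@@](C)(O)C(=O)SCC(=O)OC(C)(C)C)(CC1)[S+]2[O-]` gives 2.6 nM and compound 2 `COC1(O[C@@H]2/C=C(\C)CC[C@]3([C@@](C)(O)C(=O)SCc4oc(=O)oc4C)CC(=O)N([C@H](C)c4nc(cs4)/C=C/C=C/C2=O)[S+]3[O-])CCOCC1` gives 1.4 nM, so these two stand together at the low end of the numbers, within the scatter of each other. Compound 3 `CCOC(=O)CSC(=O)[C@](C)(O)[C@@]12CC/C(C)=C/[C@@H](O)C(=O)/C=C/C=C/c3csc(n3)[C@@H](C)N(C(=O)C1)[S+]2[O-]` gives 1300 nM, a far higher number than either, beyond the scatter.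

The unmeasured compound 4 `C/C1=C\[C@@H](O[C@H]2CCCCO2)C(=O)/C=C/C=C/c2csc(n2)[C@@H](C)N2C(=O)C[C@@]([C@@](C)(O)C(=O)SCc3oc(=O)oc3C)(CC1)[S+]2[O-]` departs from compound 2 in one place, with oxan-2-yl in place of 4-methoxyoxan-4-yl on an oxygen on a saturated carbon.

Going by the values given here, only one measured step changes a single place, and it is a 500-fold higher number from compound 1 to compound 3 (2.70 log units; beyond the scatter), with ethyl in place of tert-butyl. That step is large, so a modest edit can move this read-out a long way in this series, yet it concerns a different group and says nothing direct about this oxygen. Among the compounds with values here, no measured compound carries oxan-2-yl. The starting point therefore remains compound 2 at 1.4 nM, and no shift beyond the scatter is expected, though the upper margin is kept wide. The expected change is a 1.8-fold higher number from compound 2 to compound 4 (0.25 log units; within the scatter). The estimate for compound 4 in this assay is 2.5 nM, with an expected range from 0.7 nM to 25 nM.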

Compound 4, half-maximal inhibitory concentration: 2.4 nM
Estimate against measurement, compound 4: 1.0-fold (0.02 log units) above, and the stated range covers the measured number.
By their numbers in this assay, from the lowest: compounds 2, 4 and 1 (each within the scatter of the next); then compound 3.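

In this assay, oxan-2-yl in place of 4-methoxyoxan-4-yl on this oxygen gives a 1.7-fold higher number from compound 2 to compound 4 (0.23 log units; within the scatter) and so leaves the read-out within the scatter, at the low end of the numbers. Going by these compounds alone, this is the first single-place step at this oxygen, and it shows that the methoxy group can go and the ring can be attached differently, with a defined stereocentre entering, without any shift that can be told from the scatter, whereas the only other such step, a 500-fold higher number from compound 1 to compound 3 (2.70 log units; beyond the scatter), belongs to a different group and is large. No measurement is at hand that would explain why this exchange leaves the number within the scatter.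

Going by these compounds, both groups seen on this oxygen are six-membered non-aromatic rings with one hetero atom, so it remains open whether an open chain such as butyl, or a group carrying an amine or a carboxylic acid, would be tolerated here as well. Also open is how the other configuration at the stereocentre of oxan-2-yl would read in this assay, since only one form of this group appears among these compounds.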